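Shortening a chain on the core of compound 2

This account rests on a few compounds, and the source may have more. Where it says the series, first, only, none or still open, it means among the compounds named here.

Measured so far:
compound 1 `CN(C)CCNc1ccnc2cc(OCc3ccc(F)cc3)ccc12`: 890 nM
compound 2 `CCCCCCCCOc1ccc2c(Cl)ccnc2c1`: 4300 nM

Both compounds were tested in a functional assay on SK-OV-3 cells (Homo sapiens) for cytotoxicity, read by MTT assay, with a stated time of 48 h; on this read-out lower numbers stand for stronger inhibition and higher numbers for weaker inhibition. Of the two, compound 2 gives the higher number, so it is the weaker of the pair; its value sits well apart from that of compound 1, beyond the usual scatter of repeated measurements.

Compound 3 `CCOc1ccc2c(Cl)ccnc2c1` has not yet been measured. It differs from compound 2 in one place: hydrogen in place of hexyl on a saturated chain carbon, two bonds along the chain from an oxygen on an aromatic ring. The long chain attached through the oxygen on the aromatic ring is thus cut back to a short one, while the rest of the core stays as it is.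

Going by the values given here, no measured pair shows what such a chain shortening does on this core, so the expectation rests on compound 2 alone. For compound 3 a weaker result is expected, with a step of a 2.8-fold higher number from compound 2 to compound 3 (0.45 log units; beyond the scatter). The estimate for compound 3 is 12000 nM, with a range from 4000 nM to 40000 nM.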

Compound 3, half-maximal inhibitory concentration: 3460 nM
Compound 3: the middle estimate sits 3.5-fold (0.54 log units) above what was measured; measured number outside the range, below it.
By their numbers in this assay, from the lowest: compound 1; then compounds 3 and 2 (each within the scatter of the next).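

In this assay, putting hydrogen in place of hexyl on a saturated chain carbon, two bonds along the chain from an oxygen on an aromatic ring, gives a 1.2-fold lower number from compound 2 to compound 3 (0.09 log units; within the scatter) on the shared core. Going by these compounds alone, this is the first reading of this position, and it shows that the long and the short chain cannot be told apart in this test: with or without the hexyl part, the two compounds sit at the same level. The data at hand offer no explanation for this result.

Going by these compounds, whether an amine or a phenyl ring in place of hydrogen on that same chain carbon would move the number away from this level remains open. Compound 1 differs from compound 3 in more than one place, so the compounds shown do not say which of its features goes with its lower number.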